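Widening the benzyl group of compound 1 to naphthalene

This account rests on a few compounds, and the source may have more. Where it says the series, first, only, none or still open, it means among the compounds named here.

In a functional assay on A2780 cells (Homo sapiens) for inhibition, read by MTT assay, with a stated time of 72 h (on this read-out higher numbers stand for weaker inhibition and lower numbers for stronger inhibition), compound 1 `Cc1cccc(CN2CCc3ncn(COCc4ccccc4)c3/C(=C/c3ccccc3)C2=O)c1` gives 26300 nM and compound 3 `O=C1/C(=C\c2ccc(C(F)(F)F)cc2)c2c(ncn2COCc2ccccc2)CCN1Cc1ccccc1` gives 28200 nM, two values within the scatter of each other. Compound 2 `O=C1/C(=C\c2ccncc2)c2c(ncn2COCc2ccccc2)CCN1Cc1ccccc1` reads > 100000 nM, which is a limit of the assay and not a number. Among the compounds with values here, compound 1 therefore stands level with compound 3, and these are the only two numbers so far.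

The next compound is compound 4 `O=C1/C(=C\c2ccccc2)c2c(ncn2COCc2ccccc2)CCN1Cc1ccc2ccccc2c1`, which has naphthalen-2-yl in place of 3-methylphenyl on a saturated chain carbon bound to an amide-type nitrogen in a ring.

One measured step exists, an at least 3.5-fold lower number from compound 2 to compound 3 (0.54 log units; beyond the scatter). It bears on this change only weakly, since it replaces pyridin-4-yl at a different place, on a double-bonded chain carbon, and it starts from the limit of > 100000 nM in this assay, at which 1 of the 3 values shown sits. Within the data shown here, no measured step covers the saturated chain carbon bound to the amide-type nitrogen, so no direction can be drawn from the data. A change beyond the scatter in this assay is therefore not expected, although the uncertainty is wide in both directions. The estimated step is a 1.3-fold lower number from compound 1 to compound 4 (0.12 log units; within the scatter). For compound 4 the expected value is 20000 nM, with an estimated range of 7000 nM to 60000 nM.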

Compound 4, half-maximal inhibitory concentration: 72800 nM
Beside the measured number, compound 4's estimate is 3.6-fold (0.56 log units) below it; the whole stated range lies below it.
By their numbers in this assay, from the lowest: compounds 1 and 3 (each within the scatter of the next); then compound 4. At a limit, above all of these: compound 2.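

In this assay, within the data shown here, this is the first measured step at the saturated chain carbon bound to an amide-type nitrogen in a ring, and naphthalen-2-yl in place of 3-methylphenyl gives a 2.8-fold higher number from compound 1 to compound 4 (0.44 log units; beyond the scatter). The place is therefore not silent on this read-out, and with this pair the second six-membered aromatic ring goes with weaker inhibition, although the step is modest and compound 4 still reads as a number rather than a limit. Any further weakening from changes at this place would have little room to be sized on this read-out: the limit of > 100000 nM in this assay, at which 1 of the 4 values shown sits.

This single pair cannot separate the effect of the second aromatic ring from the loss of the methyl group, and it does not show whether the same change would read alike with 4-(trifluoromethyl)phenyl or pyridin-4-yl on the double-bonded chain carbon. Also open, as far as these compounds go, is how the number would move with a smaller group at this place, such as a plain methyl, or with an amine or a carboxylic acid on the phenyl ring.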